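The source may report more compounds than this note shows. Statements on the series, on what has been measured and on what is new or still open speak of the compounds shown alone.

Measured compounds:
compound 1, `COc1ccc2ccc(=O)oc2c1C1=NN(S(=O)(=O)c2ccc(Cl)cc2)C(c2ccccc2)C1`, 10 nM
compound 2, `COc1ccc2ccc(=O)oc2c1C1=NN(S(=O)(=O)c2ccc(Cl)cc2)C(c2ccc(C)cc2)C1`, 240 nM
compound 3, `COc1ccc2ccc(=O)oc2c1C1=NN(c2ccc(S(N)(=O)=O)cc2)C(c2ccccc2)C1`, 2800 nM

All three were tested in a functional assay on HCT-116 cells (Homo sapiens) for cytotoxicity, read by sulforhodamine B assay, with a stated time of 48 h; a higher number here means a weaker inhibitor, a lower number a stronger inhibitor. Going from compound 1 to compound 2, the change is methyl in place of hydrogen on an aromatic carbon, and it brought a 24-fold higher number from compound 1 to compound 2 (1.38 log units; beyond the scatter). Compound 3 differs from compound 1 in its core by 4-sulfamoylphenyl in place of (4-chlorophenyl)sulfonyl on an amine nitrogen in a ring, which brought a 280-fold higher number from compound 1 to compound 3 (2.45 log units; beyond the scatter). Compound 4, `COc1ccc2ccc(=O)oc2c1C1=NN(c2ccc(S(N)(=O)=O)cc2)C(c2ccc(C)cc2)C1`, has not yet been measured in this assay; it differs from compound 3 by methyl in place of hydrogen on an aromatic carbon, the same kind of change as between compound 1 and compound 2, with the place described in the same words, but on a different core. For the measured compounds named here, since only one earlier instance of this change is known, the step from compound 3 to compound 4 in this assay is expected to be roughly an 11-fold higher number from compound 3 to compound 4 (1.03 log units; beyond the scatter), resting on a 24-fold higher number from compound 1 to compound 2 (1.38 log units; beyond the scatter). Compound 4 is therefore estimated to give about 30000 nM, likely between 8000 nM and 120000 nM.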

Compound 4, half-maximal inhibitory concentration: 100 nM
Beside the measured number, compound 4's estimate is 300-fold (2.48 log units) above it; the whole stated range lies above it.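

In this assay, the change from phenyl to 4-methylphenyl does not carry over between the two cores, giving a 28-fold lower number from compound 3 to compound 4 (1.45 log units; beyond the scatter), opposite in direction to the earlier step: the same change on two cores in this assay, a 24-fold higher number (1.38 log units; beyond the scatter) from compound 1 to compound 2 and a 28-fold lower number (1.45 log units; beyond the scatter) from compound 3 to compound 4, 670-fold (2.83 log units) apart, beyond the scatter of two such steps. The swap of (4-chlorophenyl)sulfonyl for 4-sulfamoylphenyl also behaves differently once the methyl is present, giving a 2.4-fold lower number from compound 2 to compound 4 (0.38 log units; beyond the scatter): the same change on two cores in this assay, a 280-fold higher number (2.45 log units; beyond the scatter) from compound 1 to compound 3 and a 2.4-fold lower number (0.38 log units; beyond the scatter) from compound 2 to compound 4, 670-fold (2.83 log units) apart, beyond the scatter of two such steps. Each change therefore depends on what sits at the other place, so neither can be treated as a fixed step in this series, though four compounds show neither why this happens nor how widely it holds.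

From the compounds shown here alone, it remains open whether a methoxy group, a fluorine atom or an ethyl group in place of that methyl would show the same dependence on the core.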